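The source may hold more compounds than are shown below. What is called first, only, known or untested is meant among the compounds shown, and "the series" means these compounds.

Measured compounds in a functional assay, read by spectrophotometry, with a stated time of 30 min; on this read-out lower numbers stand for stronger inhibition and higher numbers for weaker inhibition:
compound 1, `Cc1nc2c3ccccc3ccc2c2nc3c(ccc4ccccc43)c(-c3cccc([N+](=O)[O-])c3)c12`, 117 ug/mL
compound 2, `Cc1nc2c3ccccc3ccc2c2nc3c(ccc4ccccc43)c(-c3ccccc3N)c12`, 95.4 ug/mL
compound 3, `Cc1nc2c3ccccc3ccc2c2nc3c(ccc4ccccc43)c(-c3ccccc3S)c12`, 89 ug/mL

Compound 3 gives the lowest of the three numbers, yet its gaps to the others, a 1.1-fold lower number from compound 2 to compound 3 (0.03 log units; within the scatter) and a 1.3-fold lower number from compound 1 to compound 3 (0.12 log units; within the scatter), both lie within the scatter. Compound 4, `Cc1ccc(-c2c3ccc4ccccc4c3nc3c2c(C)nc2c4ccccc4ccc32)cc1`, differs from compound 3 in one place: 4-methylphenyl in place of 2-sulfanylphenyl on an aromatic carbon. Going by the values given here, the steps that bear on this change are those that exchanged the same phenyl group, a 1.2-fold lower number from compound 1 to compound 2 (0.09 log units; within the scatter) and a 1.3-fold lower number from compound 1 to compound 3 (0.12 log units; within the scatter); each stayed within the scatter. With three different phenyl groups giving numbers this close, no step beyond the scatter is expected in this assay for the fourth. Compound 4 is therefore estimated at 95 ug/mL, with a range from 45 ug/mL to 200 ug/mL. That expectation means a 1.1-fold higher number from compound 3 to compound 4 (0.03 log units; within the scatter).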

Compound 4, half-maximal inhibitory concentration: 123 ug/mL
Compound 4: the middle estimate sits 1.3-fold (0.11 log units) below what was measured, and the stated range covers the measured number.
By their numbers in this assay, from the lowest: compounds 3, 2, 1 and 4 (each within the scatter of the next).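

In this assay, the 4-methylphenyl group, built of carbon only, stays within the scatter of all three earlier phenyl groups: a 1.4-fold higher number from compound 3 to compound 4 (0.14 log units; within the scatter), a 1.3-fold higher number from compound 2 to compound 4 (0.11 log units; within the scatter) and a 1.1-fold higher number from compound 1 to compound 4 (0.02 log units; within the scatter). Across these four compounds, then, replacing the 2-sulfanylphenyl, 2-aminophenyl or 3-nitrophenyl group with one that has only a methyl on the ring does not shift the number beyond the scatter. Nothing measured here gives a reason for this. Still open, on these data alone, is whether something other than a substituted phenyl at this position, such as a carboxylic acid or a longer alkyl chain, would move the number.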